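Cyclohexyl for Fluorophenyl on a Triazole-Linked Amide

The compounds below may be only part of what the source reports. "The series", "measured", "known", "first", "only" and "open" are said of these compounds alone.

The measured compounds:
compound 1, `Nc1nn(Cc2cn(-c3cccc(Cl)c3)nn2)c2nc(-c3ccccc3)cc(C(F)(F)F)c12`, 32.4 ug/mL
compound 2, `Nc1nn(Cc2cn(-c3ccc(O)c([N+](=O)[O-])c3)nn2)c2nc(-c3ccccc3)cc(C(F)(F)F)c12`, 41.3 ug/mL
compound 3, `Nc1nn(Cc2cn(CC(=O)Nc3cccc(F)c3)nn2)c2nc(-c3ccccc3)cc(C(F)(F)F)c12`, 43.5 ug/mL

In a functional assay on U-937 cells (Homo sapiens) for cytotoxicity, read by MTT assay, with a stated time of 24 h (a higher number here means a weaker inhibitor, a lower number a stronger inhibitor), compound 3 has the highest of the three numbers, but the steps of a 1.1-fold higher number from compound 2 to compound 3 (0.02 log units; within the scatter) and a 1.3-fold higher number from compound 1 to compound 3 (0.13 log units; within the scatter) are both within the scatter, so no order among the three can be read from these values. Compound 4, `Nc1nn(Cc2cn(CC(=O)NC3CCCCC3)nn2)c2nc(-c3ccccc3)cc(C(F)(F)F)c12`, is not yet measured. It differs from compound 3 in one place: cyclohexyl in place of 3-fluorophenyl on an amide-type nitrogen. Among the compounds with values here, no measured step changes a group on the amide-type nitrogen, so none bears on this change directly. What the three steps do show, including a 1.3-fold higher number from compound 1 to compound 2 (0.11 log units; within the scatter), is that swapping the group on the aromatic nitrogen of the shared core leaves this assay unmoved. On that basis the expected step of a 1.0-fold lower number from compound 3 to compound 4 (0.02 log units; within the scatter) is none beyond the scatter. Compound 4 is therefore estimated at 42 ug/mL, with a range from 24 ug/mL to 75 ug/mL.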

Compound 4, half-maximal inhibitory concentration: 89 ug/mL
Compound 4: middle estimate off by 2.1-fold (0.33 log units), on the low side, and the stated range ends below it.
By their numbers in this assay, from the lowest: compounds 1, 2 and 3 (each within the scatter of the next); then compound 4.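

In this assay, within the data shown here, the amide-type nitrogen proves to be a place where the number can move: with cyclohexyl in place of 3-fluorophenyl there is a 2.0-fold higher number from compound 3 to compound 4 (0.31 log units; beyond the scatter) and this is the first single change in the set to pass the scatter, if only modestly. Read as a change on the aromatic nitrogen of the shared core, the (cyclohexylcarbamoyl)methyl group also gives a 2.2-fold higher number from compound 2 to compound 4 (0.33 log units; beyond the scatter) and a 2.7-fold higher number from compound 1 to compound 4 (0.44 log units; beyond the scatter) so this group stands apart, whereas compound 1, compound 2 and compound 3 stayed within the scatter of each other. No measurement here bears on why the number rises with this change.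

A single amide pair cannot separate the loss of the aromatic ring from the loss of the fluorine. As far as these compounds go, whether an unsubstituted phenyl, a benzyl, an open-chain butyl or a morpholine on that nitrogen would sit with compound 3 or with compound 4 remains open.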